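From 3-methoxyphenyl to 4-methoxyphenyl on a carbonyl carbon

The source may report more compounds than this note shows. Statements on the series, on what has been measured and on what is new or still open speak of the compounds shown alone.

In an ADME assay on Vero cells (Chlorocebus sabaeus) for cytotoxicity, read by MTT assay, with a stated time of 48 h (a higher number here means a weaker inhibitor, a lower number a stronger inhibitor), compound 1 `CS(=O)(=O)NC1CCC(CN2CCN(c3cc(=O)c4cc(C(F)(F)F)cc([N+](=O)[O-])c4s3)CC2)CC1` gives 48.5 ug/mL. Compound 2 `O=c1cc(N2CCN(CC3CCC(NS(=O)(=O)c4ccccc4)CC3)CC2)sc2c([N+](=O)[O-])cc(C(F)(F)F)cc12` reads > 64 ug/mL, which is a limit of the assay and not a number. Compound 3 `COc1cccc(C(=O)OC2CCC(CN3CCN(c4cc(=O)c5cc(C(F)(F)F)cc([N+](=O)[O-])c5s4)CC3)CC2)c1` reads > 64 ug/mL, which is likewise only a limit. Compound 3 therefore has no exact place on the scale, and it stands at the limit of > 64 ug/mL in this assay, at which 2 of the 3 values shown sit.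

Compound 4 `COc1ccc(C(=O)OC2CCC(CN3CCN(c4cc(=O)c5cc(C(F)(F)F)cc([N+](=O)[O-])c5s4)CC3)CC2)cc1` has the same atoms as compound 3, joined differently: 4-methoxyphenyl in place of 3-methoxyphenyl on a carbonyl carbon. In short, 4-methoxyphenyl stands in place of 3-methoxyphenyl on a carbonyl carbon.

Among the measured compounds shown here, no measured step covers this exact change, so the evidence is indirect. Two steps start from compound 1: an at least 1.3-fold higher number from compound 1 to compound 2 (0.12 log units; that floor lies within the scatter) and an at least 1.3-fold higher number from compound 1 to compound 3 (0.12 log units; that floor lies within the scatter). Neither floor goes beyond the scatter, although each exchanges a whole group rather than changing only the methoxyphenyl name. The remaining comparison is a step that the two limits leave unreadable from compound 2 to compound 3, so it gives no size to work from.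

Nothing measured points to a real change in this assay, so no step beyond the scatter is expected, in either direction. The expected step is a step that the limit leaves unreadable from compound 3 to compound 4. A report as a limit, rather than a number, is thought likely. The estimate for compound 4 is 70 ug/mL, with an expected range from 35 ug/mL to 130 ug/mL.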

Compound 4, half-maximal inhibitory concentration: > 64 ug/mL
Compound 4 was reported as a limit; the forecaster's own chance of this, stated with the estimate: 70%; the middle value lies beyond the limit too.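

In this assay compound 4 gives > 64 ug/mL, which is a limit and not a number. The result shows that 4-methoxyphenyl on this carbonyl carbon, like the 3-methoxyphenyl of compound 3, gives a report as a limit, so this position now has two methoxyphenyl esters read only in that form. The one step that can be read is an at least 1.3-fold higher number from compound 1 to compound 4 (0.12 log units; that floor lies within the scatter), the steps among the compounds reported as limits cannot be read, and the limit now accounts for most of the values shown: the limit of > 64 ug/mL in this assay, at which 3 of the 4 values shown sit.

From the compounds shown here alone, the exact values of compound 3 and compound 4 remain unknown, so it stays open whether moving the methoxy group between these two placings changes the reading in this assay at all. Going by these compounds, it also stays open whether an amine or a carboxylic acid in place of the methoxy group on this phenyl ring would give a reading as an exact number.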